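The source may report more compounds than this note shows. Statements on the series, on what has been measured and on what is new or still open speak of the compounds shown alone.

Measured so far:
- compound 2 `Cc1cccc2c1OCN(c1ccc3oc(-c4ccccc4)cc(=O)c3c1)C2`: 60.9%
- compound 3 `O=c1cc(-c2ccccc2)oc2cc(N3COc4c(Br)cccc4C3)ccc12`: 5.64%
- compound 1 `Cc1cc(C)c2c(c1)CN(c1ccc3c(=O)cc(-c4ccccc4)oc3c1)CO2`: "not active" (no number reported)

In a functional assay on MCF7 cells (Homo sapiens) for inhibition, read by MTT assay, with a stated time of 48 h, tested at 15 ug/mL (on this read-out higher numbers stand for more inhibition of growth at the one concentration tested and lower numbers for less inhibition of growth), compound 2 gives 60.9%, the highest of the two numbers reported. Compound 3 gives 5.64%, a gap beyond the scatter, and compound 1 is reported as "not active" (no number reported) without a number. Compound 4 `O=c1cc(-c2ccccc2)oc2ccc(N3COc4c(Br)cccc4C3)cc12` is not yet measured; it differs from compound 2 by bromo in place of methyl on an aromatic carbon. Among the compounds with values here, no step of this kind between measured compounds is known. Within the data shown here, the only bromo-bearing compound measured, compound 3, sits low, so a downward step in this assay is expected for compound 4, of uncertain size. The estimate for compound 4 is 30% with a range of 5% to 60%, meaning an expected step of a number 30.9 percentage points lower from compound 2 to compound 4 (beyond the scatter).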

Compound 4, percent growth inhibition at one concentration: 37.8%
Compound 4: middle estimate off by 7.8 percentage points, on the low side; the measured number falls inside the stated range.
By their numbers in this assay, from the lowest: compound 3; then compound 4; then compound 2.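

In this assay, bromo in place of methyl on an aromatic carbon, ortho to a fused ring, gives a number 23.1 percentage points lower from compound 2 to compound 4 (beyond the scatter). Within the data shown here, this is the first single-place step, and it shows that growth inhibition at this position responds to the swap without being lost, since compound 4 still has a measured number. Nothing available bears on why the step occurs.

On these data alone, whether chloro, methoxy or an amine at this position would stay near methyl or bromo remains open. One pair also cannot show whether the step would recur on another core.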